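Thiourea series: Vero cell cytotoxicity, towards a nitro analogue

The source may hold more compounds than are shown below. What is called first, only, known or untested is meant among the compounds shown, and "the series" means these compounds.

Measured compounds:
compound 1 `COc1cccc(NC(=S)Nc2cccc(C(F)(F)F)c2)c1`: 20000 nM
compound 2 `CCCCc1ccc(NC(=S)Nc2cccc(C(F)(F)F)c2)c(C)c1`: 18000 nM
compound 3 `CC[C@H]1CC[C@H](c2ccc(NC(=S)Nc3cccc(C(F)(F)F)c3)cc2)CC1`: 10000 nM

In an ADME assay on Vero 76 cells (Chlorocebus sabaeus) for cytotoxicity, read by crystal violet staining, with a stated time of 96 h (on this read-out lower numbers stand for higher toxicity in this test and higher numbers for lower toxicity in this test), compound 1 gives 20000 nM, compound 2 gives 18000 nM and compound 3 gives 10000 nM. Compound 3 has the lowest of the three numbers, but its gaps to compound 2 and to compound 1 both fall within the usual scatter of this assay, so nothing can be read as an order among the three; all sit in the same band.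

Compound 4 `O=[N+]([O-])c1ccc(NC(=S)Nc2cccc(C(F)(F)F)c2)cc1` is not yet measured. Relative to compound 3 it differs by nitro in place of 4-ethylcyclohexyl on an aromatic carbon. Within the data shown here, there is no measured pair in this set that isolates such a change, so the expectation rests only on the narrow band the three measured compounds occupy. The step from compound 3 to compound 4 is expected to be small, at most a modest move toward a higher number, and may well stay within the scatter: a 2.0-fold higher number from compound 3 to compound 4 (0.30 log units; within the scatter). For compound 4 the expected value in this assay is 20000 nM, with a range of 8000 nM to 50000 nM.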

Compound 4, half-maximal cytotoxic concentration: 10000 nM
Compound 4: middle estimate off by 2.0-fold (0.30 log units), on the high side; the range from low to high includes it.
By their numbers in this assay, from the lowest: compounds 3, 4, 2 and 1 (each within the scatter of the next).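

In this assay, nitro in place of 4-ethylcyclohexyl on an aromatic carbon, para to a large group, gives no change at the digits printed from compound 3 to compound 4 (within the scatter). Among these compounds, this is the first comparison that differs in one place, and it shows that this position takes two very different groups with no readable shift: a ring of carbon only with two defined stereocentres leaves, and a small group with no ring and with hydrogen-bond acceptors enters. Nothing available here explains why the read-out stays flat across this change.

From the compounds shown here alone, whether an amine or a carboxylic acid at this position would stay in the same band remains open. One pair also cannot show whether the flat result would hold if the trifluoromethyl group of the shared core gave way to another group.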